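This account rests on a few compounds, and the source may have more. Where it says the series, first, only, none or still open, it means among the compounds named here.

Compound 1 `Cc1cc(S(N)(=O)=O)ccc1NC(=O)COc1ccc(F)cc1Oc1ccc2ccccc2c1` and compound 2 `Cc1cc(S(N)(=O)=O)ccc1NC(=O)COc1ccc(Cl)cc1Oc1ccc2ccccc2c1` share a core and differ only in one halogen. In an ADME assay on C8166 cells (Homo sapiens) for cytotoxicity, read by MTT assay (a lower number here means that less compound is tolerated, a higher number that more compound is tolerated), compound 1 gives 68600 nM, and compound 2 gives 119000 nM; the step of a 1.7-fold higher number from compound 1 to compound 2 (0.24 log units; within the scatter) is the only measured one, and it lies within the scatter. Compound 2 therefore stands at the highest of the two numbers, with compound 1 within the scatter of it, so no order between them can be claimed.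

Compound 3 `Cc1cc(S(N)(=O)=O)ccc1NC(=O)COc1ccc(Cl)cc1Oc1ccc2ccccc2c1Br` differs from compound 2 by bromo in place of hydrogen on an aromatic carbon. Going by the values given here, no measured step bears on this change; the one step measured, a 1.7-fold higher number from compound 1 to compound 2 (0.24 log units; within the scatter), concerns a different position and was within the scatter. Without any guiding step, compound 3 is expected to show no step beyond the scatter, a 1.2-fold lower number from compound 2 to compound 3 (0.08 log units; within the scatter). Compound 3 is thus estimated at 100000 nM, with a range from 40000 nM to 250000 nM.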

Compound 3, half-maximal cytotoxic concentration: 48100 nM
Beside the measured number, compound 3's estimate is 2.1-fold (0.32 log units) above it; low and high end bracket the measured number.
By their numbers in this assay, from the lowest: compounds 3, 1 and 2 (each within the scatter of the next, the first and the last beyond it).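

In this assay, going by these compounds alone, the change from naphthalen-2-yl to 1-bromonaphthalen-2-yl gives the first step in this set that lies beyond the scatter (a 2.5-fold lower number from compound 2 to compound 3 (0.39 log units; beyond the scatter)), although it is a modest one. This carbon, ortho to a fused ring and ortho to a large group, is therefore a place where a single bromo shifts the number, whereas the halogen exchange at the other position stayed within the scatter (a 1.7-fold higher number from compound 1 to compound 2 (0.24 log units; within the scatter)). Nothing measured here accounts for this shift.

Going by these compounds, it remains open whether the lower number belongs to bromo in particular or would also follow from another group on this carbon, such as a methyl, a methoxy or an amine. On these data alone, it is also open whether bromo here would give a similar step with fluoro in place of chloro, as in compound 1.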